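Piperidin-1-yl in place of the arylamino group

This account rests on a few compounds, and the source may have more. Where it says the series, first, only, none or still open, it means among the compounds named here.

Measured in a functional assay on ECa-109 cells for inhibition, with ECa-109 cell line (Homo sapiens) as the target, read by sulforhodamine B assay; a higher number here means a weaker inhibitor, a lower number a stronger inhibitor:
- compound 1 `O=C1C(Nc2ccccc2F)=CC(=O)c2c1nc1n2[C@H]2OC[C@@H](O)[C@H]2OC1`: 2660 nM
- compound 2 `CCc1ccc(NC2=CC(=O)c3c(nc4n3[C@H]3OC[C@@H](O)[C@H]3OC4)C2=O)cc1`: > 4000 nM (a limit)
- compound 3 `O=C1C=C(NC2CCCC2)C(=O)c2c1nc1n2[C@H]2OC[C@@H](O)[C@H]2OC1`: > 16000 nM (a limit)

Compound 2 has no number, only the limit > 4000 nM. Compound 4 `O=C1C(N2CCCCC2)=CC(=O)c2c1nc1n2[C@H]2OC[C@@H](O)[C@H]2OC1` carries piperidin-1-yl in place of (4-ethylphenyl)amino on a double-bonded ring carbon. Among the measured compounds shown here, the one measured step, an at least 1.5-fold higher number from compound 1 to compound 2 (0.17 log units; that floor lies within the scatter), exchanges one aromatic group for another and has a floor within the scatter, so it bears only weakly on this change. A higher number is expected because compound 3 without an aromatic ring on its amine nitrogen gives the limit > 16000 nM. The expected step is a step that the limit leaves unreadable from compound 2 to compound 4, a modest one. For compound 4 the estimate is 10000 nM, with an expected range of 3500 nM to 30000 nM.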

Compound 4, half-maximal inhibitory concentration: > 8000 nM
Compound 4 was reported as a limit (the forecaster's own chance of this, stated with the estimate: 60%); the middle value is on the limit's open side.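

In this assay, among the compounds shown here, piperidin-1-yl on the double-bonded ring carbon gives an at least 3.0-fold higher number from compound 1 to compound 4 (0.47 log units; beyond the scatter), the first step at this position that lies beyond the scatter. Compound 4 is reported only as a limit, > 8000 nM. The step from compound 2 to compound 4 cannot be read, as both values are limits.

On these data alone, whether the higher number goes with the lost aromatic ring or the lost hydrogen-bond donor remains open. An N-methyl-N-phenylamino group on the same carbon would separate the two.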